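The compounds below may be only part of what the source reports. "The series", "measured", "known", "first", "only" and "open" are said of these compounds alone.

For the measured compounds named here, in a functional assay on HeLa cells (Homo sapiens) for antiproliferative activity, read by MTT assay, with a stated time of 72 h (a higher number here means a weaker inhibitor, a lower number a stronger inhibitor), no tested compound has yet given a readable number. Compound 1 (`COc1cc(-c2ncnn2-c2cccc(F)c2)cc(OC)c1OC`) gives > 10000 nM, which is a limit of the assay and not a number. Compound 2 (`COc1cc(-n2ncnc2-c2ccc(Cl)cc2)cc(OC)c1OC`) gives > 10000 nM, again a limit. Compound 3 (`COc1cccc(-c2ncnn2-c2cc(OC)c(OC)c(OC)c2)c1`) gives > 10000 nM, also a limit, so its standing is known only as that limit. The whole picture so far is the limit of > 10000 nM in this assay, at which 3 of the 3 values shown sit.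

Compound 4 (`COc1cc(-n2ncnc2-c2cccc(Cl)c2)cc(OC)c1OC`) has chloro in place of methoxy on an aromatic carbon, meta to a large group, turning 3-methoxyphenyl into 3-chlorophenyl: chloro in place of methoxy on an aromatic carbon. Going by the values given here, the one measured step that bears on this change is a step that the two limits leave unreadable from compound 2 to compound 3, so it offers no size to carry over. With nothing larger to go on, no step beyond the scatter can be forecast in this assay, and no direction either. The expected change, a step that the limit leaves unreadable from compound 3 to compound 4, is therefore only an estimate resting on the limit reached by compound 3. For compound 4 the estimate is 15000 nM, with an expected range from 3000 nM to 50000 nM, and a report of only a limit is the likeliest outcome.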

Compound 4, half-maximal inhibitory concentration: > 10000 nM
Compound 4: only a limit was reported (the forecaster's own chance of this, stated with the estimate: 85%); the middle value does not contradict the limit.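

Compound 4 is reported only as a limit, as are compound 2 and compound 3, so the steps to compound 4 from those two compounds cannot be read. Whether any of these changes alters potency stays open, with no readable number yet among the compounds shown: the limit of > 10000 nM in this assay, at which 4 of the 4 values shown sit.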